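Swapping Methyl for Chloro on the Pendant Aromatic Ring

The compounds below may be only part of what the source reports. "The series", "measured", "known", "first", "only" and "open" are said of these compounds alone.

Among the measured compounds shown here, compound 3 `Cc1cccc([C@@H]2C[C@H](O)Cc3ccccc3N2)c1` is the one compound here with a genuine number in an ADME assay on THP-1 cells (Homo sapiens) for cytotoxicity, read by MTT assay, with a stated time of 72 h; on this read-out higher numbers stand for lower toxicity in this test and lower numbers for higher toxicity in this test: compound 3 gives 176000 nM. Compound 1 `O[C@@H]1Cc2ccccc2N[C@H](c2ccccc2)C1` reaches only a limit of the test, > 300000 nM. Compound 2 `COc1cccc([C@@H]2C[C@H](O)Cc3ccccc3N2)c1` likewise stops at a limit, > 300000 nM. Between them lies a step that the two limits leave unreadable from compound 1 to compound 2. Compound 4 `O[C@@H]1Cc2ccccc2N[C@H](c2cccc(Cl)c2)C1` differs from compound 3 by chloro in place of methyl on an aromatic carbon. For the measured compounds named here, no measured step exchanges methyl for chloro; the nearest are an at least 1.7-fold lower number from compound 1 to compound 3 (0.23 log units; that floor lies within the scatter) and an at least 1.7-fold lower number from compound 2 to compound 3 (0.23 log units; that floor lies within the scatter), both small floors. A change of similar modest size is therefore expected in this assay, with compound 4 estimated at 150000 nM, within a range from 50000 nM to 300000 nM. That estimate means a step of a 1.2-fold lower number from compound 3 to compound 4 (0.07 log units; within the scatter), expected to stay inside the usual scatter.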

Compound 4, half-maximal cytotoxic concentration: 167000 nM
Estimate against measurement, compound 4: 1.1-fold (0.05 log units) below; the range from low to high includes it.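

In this assay, chloro in place of methyl gives a 1.1-fold lower number from compound 3 to compound 4 (0.02 log units; within the scatter), so at this place, meta to a large group, the two groups cannot be told apart. Chloro in place of methoxy gives an at least 1.7-fold lower number from compound 2 to compound 4 (0.25 log units; that floor lies within the scatter), and chloro in place of hydrogen gives an at least 1.7-fold lower number from compound 1 to compound 4 (0.25 log units; that floor lies within the scatter). Both steps are only floors, and their true size stays unknown because compounds 1 and 2 each stop at a limit: the limit of > 300000 nM in this assay, at which 2 of the 4 values shown sit.

Going by these compounds, it remains open whether an amine or a carboxylic acid at this place would shift the number beyond the scatter. A longer chain there is equally untested among the compounds shown.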